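A chloro to methoxy exchange under test

A few compounds are considered here, and "the series" means these few. Any claim that something is new, unique, unknown or untested is made for them only; others in the source may bear on it.

In a functional assay on HCT-116 cells (Homo sapiens) for cytotoxicity, with a stated time of 3 days (a higher number here means a weaker inhibitor, a lower number a stronger inhibitor), compound 1 (`C#Cc1nc2ccccc2[se]1`) gives 25000 nM as its half-maximal inhibitory concentration. Compound 2 (`C#Cc1nc(C(=O)Nc2ccc(Cl)cc2)cs1`) gives 15900 nM in the same read-out. These two numbers lie within the usual scatter of each other, so compound 2 cannot be separated from compound 1. For compound 3 (`C=Cc1sc(-c2ccc(F)cc2)nc1C(=O)OCC`) the result is a limit (> 40000 nM), not a number.

Compound 4 (`C#Cc1nc(C(=O)Nc2ccc(OC)cc2)cs1`) has not yet been measured. It differs from compound 2 in one place, with methoxy in place of chloro on an aromatic carbon, para to a large group (methoxy in place of chloro on an aromatic carbon). Among the compounds with values here, no measured pair in this small set shows a step of any kind, so the expectation rests on the reading for compound 2 (15900 nM) alone. In this assay no step beyond the scatter is expected, with a slight lean towards a higher number, and the estimated step of a 1.3-fold higher number from compound 2 to compound 4 (0.10 log units; within the scatter) stays small. Compound 4 is expected at 20000 nM (estimated range 8000 nM to 40000 nM).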

Compound 4, half-maximal inhibitory concentration: 8390 nM
Compound 4: middle estimate off by 2.4-fold (0.38 log units), on the high side, and the stated range covers the measured number.
By their numbers in this assay, from the lowest: compounds 4, 2 and 1 (each within the scatter of the next, the first and the last beyond it). At a limit, above all of these: compound 3.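

Within the data shown here, the exchange gives the first step in this set that can be read between two compounds differing in one place: a 1.9-fold lower number from compound 2 to compound 4 (0.28 log units; within the scatter). In this assay, chloro and methoxy on this aromatic carbon, para to a large group, therefore cannot be told apart, although the two groups differ in heavy atoms and in hydrogen-bond acceptors. Nothing at hand gives a cause for the size of this step.

On these data alone, what an amine, a hydroxyl or a longer chain such as ethoxy would give on this aromatic carbon stays open, so it is unknown whether any group here can move the number beyond the scatter. As far as these compounds go, it also stays open whether the same exchange would give a similar step at another place on the ring or on another core.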